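The source may hold more compounds than are shown below. What is called first, only, known or untested is meant among the compounds shown, and "the series" means these compounds.

In an ADME assay on HFF cells (Homo sapiens) for cytotoxicity, with a stated time of 8 days (a higher number here means that more compound is tolerated, a lower number that less compound is tolerated), compound 1 `CNc1nc(N)nc2c1ncn2/C=C1/CC1(CO)CO` gives 265000 nM with methylamino on the shared core. Compound 2 `C=CCOc1nc(N)nc2c1ncn2/C=C1/CC1(CO)CO` carries allyloxy in place of methylamino and reads > 300000 nM as a limit of the assay and not a number. Its standing is thus the limit of > 300000 nM in this assay, at which 1 of the 2 values shown sits, and nothing finer. The step to compound 3 `CCOc1nc(N)nc2c1ncn2/C=C1/CC1(CO)CO` is methyl in place of vinyl on a saturated chain carbon bound to an oxygen on an aromatic ring with methyl in place of vinyl on a saturated chain carbon bound to an oxygen on an aromatic ring, so allyloxy gives way to ethoxy. Among the compounds with values here, the only measured step that bears on this is an at least 1.1-fold higher number from compound 1 to compound 2 (0.05 log units; that floor lies within the scatter) and it is a different change, whose floor stays within the scatter. No move beyond the scatter is therefore expected in this assay here. The estimated step is an at least 1.0-fold lower number from compound 2 to compound 3 (0.02 log units; that floor lies within the scatter) and it is expected to stay within the scatter. Compound 3 is estimated at 280000 nM with an expected range from 150000 nM to 400000 nM and may again read as a limit.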

Compound 3, half-maximal cytotoxic concentration: > 300000 nM
Compound 3: a limit, no number; the forecaster's own chance of this, stated with the estimate: 55%; middle value at least 1.0-fold (0.02 log units) away from the limit.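

With ethoxy in place of allyloxy, the shared core still reaches the limit of this assay, so the vinyl of the allyl group is not required for that reading, and this limit now holds for both groups bound through oxygen: the limit of > 300000 nM in this assay, at which 2 of the 3 values shown sit. Set against methylamino on the aromatic carbon, ethoxy gives an at least 1.1-fold higher number from compound 1 to compound 3 (0.05 log units; that floor lies within the scatter) and so shows no move beyond the scatter, as allyloxy did. The step between compound 2 and compound 3 cannot be read, as both values are limits and not numbers.

The compounds shown leave open how far past the limit either of these groups lies. They also leave open whether a longer chain such as butoxy, or a carboxylic acid on the chain, would bring the reading down to a number.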